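Thiosemicarbazide series: ring size on the thiocarbonyl carbon

The source may hold more compounds than are shown below. What is called first, only, known or untested is meant among the compounds shown, and "the series" means these compounds.

Measured so far in a functional assay on A-431 cells (Homo sapiens) for cytotoxicity, read by MTT assay, with a stated time of 72 h, tested at 10 uM; a higher number here means more inhibition of growth at the concentration tested, a lower number less inhibition of growth:
- compound 1 `Cc1cccc(/C(N)=N/NC(=S)N2CCCCC2)n1` gives 47.8%
- compound 2 `Cc1cccc(/C(N)=N/NC(=S)N2CCCC2)n1` gives 67.6%
- compound 3 `Cc1ccnc(/C(N)=N/NC(=S)N2CCCCC2)c1` gives 39.7%

Compound 1 and compound 2 differ by one change, (pyrrolidin-1-yl in place of piperidin-1-yl on a thiocarbonyl carbon), and the step is a number 19.8 percentage points higher from compound 1 to compound 2 (beyond the scatter). Compound 3 carries a different core from compound 1; the difference between the two cores is not broken down here, and the two values lie within the scatter of each other.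

Compound 4 `Cc1ccnc(/C(N)=N/NC(=S)N2CCCC2)c1` is not yet measured. It differs from compound 3 by pyrrolidin-1-yl in place of piperidin-1-yl on a thiocarbonyl carbon, the same change as from compound 1 to compound 2, at the same place. Going by the values given here, the step is expected to be about a number 17.3 percentage points higher from compound 3 to compound 4 (beyond the scatter), resting on the single earlier instance a number 19.8 percentage points higher from compound 1 to compound 2 (beyond the scatter) in this assay. Compound 4 is thus estimated at 57%, with a range from 42% to 72%.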

Compound 4, percent growth inhibition at one concentration: 71.2%
The estimate for compound 4 lay 14.2 percentage points below the measured number; the measured number falls inside the stated range.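

Replacing piperidin-1-yl with pyrrolidin-1-yl on the thiocarbonyl carbon gives a number 31.5 percentage points higher from compound 3 to compound 4 (beyond the scatter) in this assay. The change therefore raises the number on both cores shown, and the size of the step does not separate between them: the same change on two cores in this assay, a number 19.8 percentage points higher (beyond the scatter) from compound 1 to compound 2 and a number 31.5 percentage points higher (beyond the scatter) from compound 3 to compound 4, 11.7 percentage points apart, within the scatter of two such steps

This rests on two cores, one cell line and one concentration, so it supports no rule for other cores and gives no reason for the gain. The compounds shown leave open how the number responds to other amines on the same thiocarbonyl carbon, such as azetidin-1-yl, morpholin-4-yl or an open-chain dimethylamino group. They also leave open whether the step holds at other concentrations or in other cell lines.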